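Cytotoxicity in a Macrocyclic Series: Swapping the Sulfonamide Group

A few compounds are considered here, and "the series" means these few. Any claim that something is new, unique, unknown or untested is made for them only; others in the source may bear on it.

Compound 1 `COc1ccc2c(OCC[C@@H]3NC(=O)N(C)CCCC/C=C\[C@@H]4C[C@@]4(C(=O)NS(=O)(=O)C4(C)CC4)NC3=O)cc(-c3nc(C(C)C)cs3)nc2c1F` gives 57100 nM in an ADME assay on cells (Homo sapiens) for activation; on this read-out higher numbers stand for lower toxicity in this test and lower numbers for higher toxicity in this test.
Compound 2 `COc1ccc2c(OCC[C@@H]3NC(=O)N(C)CCCC/C=C\[C@@H]4C[C@@]4(C(=O)NS(=O)(=O)C4(C)CC4)NC3=O)cc(-c3nc(C(C)C)cs3)nc2c1Br` gives 28300 nM in this assay.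
Compound 3 `COc1ccc2c(OCC[C@@H]3NC(=O)N(C)CCCC/C=C\[C@@H]4C[C@@]4(C(=O)NS(=O)(=O)C4(C)CC4)NC3=O)cc(-c3nc(C(C)C)cs3)nc2c1Cl` gives 37400 nM in this assay.

Compound 3 stands second highest of these three numbers: a 1.3-fold higher number from compound 2 to compound 3 (0.12 log units; within the scatter), and a 1.5-fold lower number from compound 1 to compound 3 (0.18 log units; within the scatter), both within the scatter. Compound 4 `COc1ccc2c(OCC[C@@H]3NC(=O)N(C)CCCC/C=C\[C@@H]4C[C@@]4(C(=O)NS(=O)(=O)N4CCC[C@H]4C#N)NC3=O)cc(-c3nc(C(C)C)cs3)nc2c1Cl` differs from compound 3 by 2-cyanopyrrolidin-1-yl in place of 1-methylcyclopropyl on a sulfonyl sulfur. All measured steps, including a 2.0-fold lower number from compound 1 to compound 2 (0.30 log units; within the scatter), concern only a halogen on an aromatic carbon and leave the sulfonyl group untouched, so none bears directly on this change. Without such a precedent, the expectation is that the number stays within the scatter of compound 3. The expected step is therefore small: a 1.1-fold lower number from compound 3 to compound 4 (0.03 log units; within the scatter). The estimate for compound 4 in this assay is 35000 nM, with a range from 14000 nM to 85000 nM.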

Compound 4, half-maximal cytotoxic concentration: 28300 nM
The estimate for compound 4 lay 1.2-fold (0.09 log units) above the measured number, within the range that was stated.
By their numbers in this assay, from the lowest: compounds 2, 4, 3 and 1 (each within the scatter of the next).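

Replacing 1-methylcyclopropyl with 2-cyanopyrrolidin-1-yl on the sulfonyl sulfur gives, in this assay, a 1.3-fold lower number from compound 3 to compound 4 (0.12 log units; within the scatter). This is the first change shown away from the aromatic halogen, and it shows that a five-membered ring carrying a nitrile and a defined stereocentre can stand at this position without moving the number beyond the scatter. Nothing measured here explains this result. On these data alone, whether an open-chain amine such as dimethylamino, or pyrrolidin-1-yl without the nitrile, would also stay within the scatter of compound 3 remains open.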